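The compounds below may be only part of what the source reports. "The series", "measured", "known", "first", "only" and "open" are said of these compounds alone.

Compound 1, `COc1cc(C(=O)N/N=C/c2ccc(F)c(F)c2)cc(OC)c1OC`: 35.1%. Compound 2, `COc1cc(C(=O)N/N=C/c2ccc(F)cc2)cc(OC)c1OC`: 76%.

In a functional assay on PC-3 cells (Homo sapiens) for antiproliferative activity, read by MTT assay, tested at 1 uM (a higher number here means a stronger effect of the compound at the concentration tested, a lower number a weaker effect), compound 2 stands as the higher of the two measured compounds, with compound 1 the nearest and well below it. Compound 3, `COc1cc(C(=O)N/N=C/c2ccccc2F)cc(OC)c1OC`, differs from compound 2 by 2-fluorophenyl in place of 4-fluorophenyl on a carbon with a double bond to nitrogen. Among the measured compounds shown here, the only measured step, a number 40.9 percentage points higher from compound 1 to compound 2 (beyond the scatter), concerns a fluoro on an aromatic carbon as well, but it is not the same change, and it shows mainly that a fluorine can shift this assay strongly. The direction for compound 3 is therefore uncertain. Compound 3 is expected to drop somewhat, by a number 21 percentage points lower from compound 2 to compound 3 (beyond the scatter). Compound 3 is estimated at 55%, within 25% to 85%.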

Compound 3, a percentage reported as inhibition, at one concentration (the size of the read-out at that concentration, not a potency): 70.6%
Estimate against measurement, compound 3: 15.6 percentage points below, within the range that was stated.
By their numbers in this assay, from the lowest: compound 1; then compounds 3 and 2 (each within the scatter of the next).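

In this assay, 2-fluorophenyl in place of 4-fluorophenyl gives a number 5.4 percentage points lower from compound 2 to compound 3 (within the scatter) so on this carbon with a double bond to nitrogen, these two groups cannot be told apart. The 3,4-difluorophenyl of compound 1 does stand apart, with a number 35.5 percentage points higher from compound 1 to compound 3 (beyond the scatter) and this holds against both groups carrying a single fluorine. Nothing available explains this difference. The compounds shown leave open how a phenyl without any fluorine would read here, and whether an amine or a carboxylic acid in place of the fluorine would keep the effect.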